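Sulfonyl substituent change: thiophen-2-yl to propyl

The source may hold more compounds than are shown below. What is called first, only, known or untested is meant among the compounds shown, and "the series" means these compounds.

Three compounds have numbers in an assay on cells for displacement of a labelled ligand from prostaglandin E2 receptor EP4 subtype (Homo sapiens), read by scintillation counting; on this read-out higher numbers stand for weaker inhibition and lower numbers for stronger inhibition. Compound 1 `COc1ccc(-c2ccc(OCc3cc(C(=O)O)oc3C)cc2)cc1OC` gives 2800 nM and compound 2 `Cc1oc(C(=O)O)cc1COc1ccc(-c2ccc(Cl)cc2)cc1` gives 1000 nM. Compound 3 `COc1ccc(-c2ccc(OCc3cc(C(=O)NS(=O)(=O)c4cccs4)oc3C)cc2)cc1` gives 3.6 nM, the lowest of the three; the nearest number is that of compound 2 and the furthest that of compound 1, both gaps beyond the scatter. Compound 4 `CCCS(=O)(=O)NC(=O)c1cc(COc2ccc(-c3ccc(OC)cc3)cc2)c(C)o1` is not yet measured. It differs from compound 3 by propyl in place of thiophen-2-yl on a sulfonyl sulfur. Within the data shown here, no pair of measured compounds differs at this position, so no measured step guides the size of the change. The expectation for the step from compound 3 to compound 4 is small, a 2.2-fold higher number from compound 3 to compound 4 (0.35 log units; beyond the scatter), within the scatter or a little weaker. Compound 4 is estimated at 8 nM, in a range from 2.5 nM to 30 nM.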

Compound 4, inhibition constant: 5 nM
The estimate for compound 4 lay 1.6-fold (0.20 log units) above the measured number; the measured number falls inside the stated range.
By their numbers in this assay, from the lowest: compounds 3 and 4 (each within the scatter of the next); then compound 2; then compound 1.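

The sulfonyl substituent now has its first measured step in this assay: propyl in place of thiophen-2-yl gives a 1.4-fold higher number from compound 3 to compound 4 (0.14 log units; within the scatter) and leaves the number unchanged within the scatter. In this one pair, the five-membered aromatic ring on the sulfonyl sulfur can be replaced by an open chain without a readable loss. No measured evidence explains this tolerance. On these data alone, whether methyl, a longer chain, phenyl or an amine on the sulfonyl sulfur would behave alike stays open. The carboxylic acid compared with the sulfonyl carbamoyl cannot be read, since compound 1 and compound 2 differ from compound 3 in more than one place.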